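Chain Extension from Compound 2 to Compound 3 in Cytotoxicity

The compounds below may be only part of what the source reports. "The series", "measured", "known", "first", "only" and "open" are said of these compounds alone.

Compound 1 `C=CCCCCc1cc2cn([C@H]3C[C@H](O)[C@@H](CO)O3)c(=O)nc2o1` and compound 2 `C#CCCCCCc1cc2cn([C@H]3C[C@H](O)[C@@H](CO)O3)c(=O)nc2o1` share one core and differ only in the side chain. In a functional assay on HEL cells (Homo sapiens) for cytotoxicity, read by microscopy (a lower number here means that less compound is tolerated, a higher number that more compound is tolerated), compound 1 reaches only the assay limit, > 200000 nM. Compound 2 likewise gives only a limit in this assay, namely > 200000 nM. The step that the two limits leave unreadable from compound 1 to compound 2 therefore cannot be read, because both values sit at the limit of > 200000 nM in this assay, at which 2 of the 2 values shown sit. Compound 3 `C#CCCCCCCc1cc2cn([C@H]3C[C@H](O)[C@@H](CO)O3)c(=O)nc2o1` carries propargyl in place of ethynyl on a saturated chain carbon, five bonds along the chain from an aromatic carbon. Among the measured compounds shown here, no measured step gives its size, so no shift beyond the scatter is expected in this assay, and compound 3 is expected to sit at the limit again. Compound 3 is thus estimated at 200000 nM, between 100000 nM and 400000 nM. The expected step is a number no higher from compound 2 to compound 3 (the limit leaves the size open).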

Compound 3, minimum cytotoxic concentration: > 200000 nM
Compound 3: only a limit was reported; the forecaster's own chance of this, stated with the estimate: 85%; the middle value sits exactly at the limit.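

Compound 3 gives only a limit, just as compound 1 and compound 2 do, so no step among these three compounds can be read. In this assay the compounds shown leave open whether any side chain on the shared core would give a real number rather than a limit.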